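Isoquinoline replacing pyrimidine at the ether of compound 3

The source may hold more compounds than are shown below. What is called first, only, known or untested is meant among the compounds shown, and "the series" means these compounds.

The three measured compounds share one core, seen in compound 1 `CCOC(=O)c1c(C)noc1OCC(=O)[C@H](CC(=O)O)NC(=O)[C@@H](NC(=O)COc1cccc2ccccc12)C(C)C`, compound 2 `CC(C)[C@H](NC(=O)COc1cccc2ccccc12)C(=O)N[C@@H](CC(=O)O)C(=O)CSc1nc(-c2ccccc2)cs1` and compound 3 `CC(C)[C@H](NC(=O)COc1cccc2ccccc12)C(=O)N[C@@H](CC(=O)O)C(=O)COc1ccncn1`, and differ only in the group on the saturated chain carbon bound to the carbonyl carbon. In a functional assay on Jurkat cells (Homo sapiens) for inhibition (on this read-out higher numbers stand for weaker inhibition and lower numbers for stronger inhibition), compound 1 gives only a limit, > 200000 nM. Compound 2 likewise returns a limit in this assay, > 200000 nM. Compound 3 also stands at a limit in this assay, > 200000 nM, so its position on the numbers is known only as the limit itself. The steps a step that the two limits leave unreadable from compound 1 to compound 2, a step that the two limits leave unreadable from compound 1 to compound 3 and a step that the two limits leave unreadable from compound 2 to compound 3 cannot be sized because of the limit of > 200000 nM in this assay, at which 3 of the 3 values shown sit.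

Compound 4 `CC(C)[C@H](NC(=O)COc1cccc2ccccc12)C(=O)N[C@@H](CC(=O)O)C(=O)COc1nccc2ccccc12` differs from compound 3 by isoquinolin-1-yl in place of pyrimidin-4-yl on an oxygen on a saturated carbon. Within the data shown here, no measured step resembles this change, and none of the three measured steps has a readable size, so the numbers so far give neither a direction nor a size for this step in this assay. Compound 4 is expected at 150000 nM, with a range from 15000 nM to 400000 nM. Expected is an at least 1.3-fold lower number from compound 3 to compound 4 (0.12 log units; that floor lies within the scatter), and a limit rather than a number remains the likelier outcome.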

Compound 4, half-maximal inhibitory concentration: 106000 nM
The estimate for compound 4 lay 1.4-fold (0.15 log units) above the measured number, and the stated range covers the measured number.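

With isoquinolin-1-yl on the oxygen on a saturated carbon, compound 4 is the only compound shown with a readable number in this assay, and the other compounds remain at a limit: the limit of > 200000 nM in this assay, at which 3 of the 4 values shown sit.

The new steps read as an at least 1.8-fold lower number from compound 3 to compound 4 (0.27 log units; that floor lies within the scatter), as an at least 1.8-fold lower number from compound 2 to compound 4 (0.27 log units; that floor lies within the scatter) and as an at least 1.8-fold lower number from compound 1 to compound 4 (0.27 log units; that floor lies within the scatter). Each is only a floor, and the steps among compound 1, compound 2 and compound 3 cannot be read.

As far as these compounds go, how far the true steps extend past these floors remains open, as does whether the added carbon-only aromatic ring or the change from two ring nitrogens to one accounts for the step from pyrimidin-4-yl to isoquinolin-1-yl. Also open, from the compounds shown here alone, is what a plain phenyl group on this oxygen, or an amine on the isoquinolin-1-yl group, would give.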